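Antiproliferative series: aryl exchange on the amide-type nitrogen

The compounds below may be only part of what the source reports. "The series", "measured", "known", "first", "only" and "open" are said of these compounds alone.

Measured so far:
compound 1 `CN(C)C(=S)N/N=C/c1ccc2cccnc2n1` gives 970 nM in a functional assay on HeLa cells (Homo sapiens) for antiproliferative activity, read by sulforhodamine B assay, with a stated time of 72 h; on this read-out higher numbers stand for weaker inhibition and lower numbers for stronger inhibition
compound 2 `N#Cc1ccc(NC(=S)N/N=C/c2ccc3ccccc3n2)cc1` gives 20000 nM in this assay
compound 3 `CC(C)c1cccc(C(C)C)c1NC(=S)N/N=C/c1ccc2ccccc2n1` gives 16400 nM in this assay

Compound 2 stands highest of the three numbers in this assay. Its nearest neighbour is compound 3, whose number lies within the usual scatter of that of compound 2, so the two cannot be ordered against each other. Compound 1, with the lowest number of the three, lies well beyond the scatter from compound 2. Within the data shown here, compounds 2 and 3 each carry an aryl group on the amide-type nitrogen and compound 1 does not; with only three compounds measured, no pattern beyond these is claimed.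

The next compound is compound 4 `S=C(N/N=C/c1ccc2ccccc2n1)Nc1cccc(Cl)c1`. It differs from compound 2 in one place: 3-chlorophenyl in place of 4-cyanophenyl on an amide-type nitrogen. Among the measured compounds shown here, no measured pair shows this exact change, so the size of the step in this assay has to be judged from the neighbours. Compounds 2 and 3 show that two different aryl groups on that nitrogen give numbers within the scatter of each other. For compound 4 a small downward step, if any beyond the scatter, is expected, a 1.7-fold lower number from compound 2 to compound 4 (0.22 log units; within the scatter). Compound 4 is expected to give 12000 nM in this assay, with a range from 4000 nM to 36000 nM.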

Compound 4, half-maximal inhibitory concentration: 52500 nM
For compound 4 the middle estimate is 4.4-fold (0.64 log units) below the measured one, and the stated range ends below it.
By their numbers in this assay, from the lowest: compound 1; then compounds 3 and 2 (each within the scatter of the next); then compound 4.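

Among these compounds, the aryl group on the amide-type nitrogen is not a silent position in this assay: exchanging 4-cyanophenyl for 3-chlorophenyl gives a 2.6-fold higher number from compound 2 to compound 4 (0.42 log units; beyond the scatter), a modest move towards weaker inhibition that the earlier compounds did not reveal. This single exchange alters both the substituent, nitrile for chlorine, and its location on the six-membered aromatic ring, as the names 4-cyanophenyl and 3-chlorophenyl show, so the step cannot be assigned to either change alone. No measurement bearing on the origin of this step is available.

The compounds shown leave open whether the substituent or its location on the ring sets the size of the step, a question that 4-chlorophenyl and 3-cyanophenyl on the same nitrogen of the shared core would address directly. They also leave open how an unsubstituted phenyl group or a non-aryl group such as piperidine or morpholine at this nitrogen would read out in this assay.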